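Replacing 3,5-dichlorophenyl with 3,5-dimethoxyphenyl

The compounds below may be only part of what the source reports. "The series", "measured", "known", "first", "only" and "open" are said of these compounds alone.

In a functional assay on NCI-H460 cells (Homo sapiens) for inhibition, read by MTT assay, with a stated time of 72 h (a lower number here means a stronger inhibitor, a higher number a weaker inhibitor), compound 1 (`Cc1nc(-c2ccccc2F)c(C(=O)N2CCN(c3cc(Cl)cc(Cl)c3)CC2)o1`) gives 165 nM and compound 2 (`Cc1nc(-c2ccc(F)cc2)c(C(=O)N2CCN(c3cc(Cl)cc(Cl)c3)CC2)o1`) gives 243 nM. Among the compounds with values here, compound 1 therefore stands within the scatter of its only measured neighbour, with a 1.5-fold higher number from compound 1 to compound 2 (0.17 log units; within the scatter) for 4-fluorophenyl in place of 2-fluorophenyl. Compound 3 (`COc1cc(OC)cc(N2CCN(C(=O)c3oc(C)nc3-c3ccccc3F)CC2)c1`) carries 3,5-dimethoxyphenyl in place of 3,5-dichlorophenyl on an amine nitrogen in a ring, on an amine nitrogen in a ring. That one measured step does not touch this place, so the data give no direct size for the change. A moderately higher number is tentatively expected in this assay, though a lower one is not excluded. Compound 3 is estimated at 400 nM, with a range of 100 nM to 1800 nM, an expected 2.4-fold higher number from compound 1 to compound 3 (0.38 log units; beyond the scatter).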

Compound 3, half-maximal inhibitory concentration: 42 nM
The estimate for compound 3 lay 9.5-fold (0.98 log units) above the measured number, and the stated range ends above it.
By their numbers in this assay, from the lowest: compound 3; then compounds 1 and 2 (each within the scatter of the next).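

At the amine nitrogen in a ring, the aryl group does move the number in this assay: 3,5-dimethoxyphenyl in place of 3,5-dichlorophenyl gives a 3.9-fold lower number from compound 1 to compound 3 (0.59 log units; beyond the scatter). Within the data shown here, the earlier fluorophenyl step stayed within the scatter, so this is the first change that exceeds it. Nothing available explains the drop.

Going by these compounds, whether the methoxy groups or the loss of chlorine drives the step remains open, as does whether an ethoxy or hydroxy group would behave alike. Also open, on these data alone, is whether the same change would hold on the 4-fluorophenyl compound 2.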